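Sulfonyl aryl swap on a shared core: nitrile variant

The compounds below may be only part of what the source reports. "The series", "measured", "known", "first", "only" and "open" are said of these compounds alone.

Measured compounds:
Compound 1 `Cc1cc(C)cc(S(=O)(=O)c2cnc3cc(F)ccc3c2N2CCC(C)CC2)c1` — 80%
Compound 2 `CC1CCN(c2c(S(=O)(=O)c3ccc(F)c(Cl)c3)cnc3cc(F)ccc23)CC1` — 94%

In an assay on isolated protein for displacement of a labelled ligand from metabotropic glutamate receptor 5 (Homo sapiens), with a stated time of 60 min, tested at 1 uM (on this read-out higher numbers stand for more inhibition at the one concentration tested (going by the name of the read-out) and lower numbers for less inhibition), compound 2 stands highest of the two numbers, and its nearest neighbour is compound 1, which gives 80%. Among the measured compounds shown here, the one step between them, a number 14 percentage points higher from compound 1 to compound 2 (beyond the scatter), is a modest rise beyond the scatter and changes the aryl group on the sulfonyl sulfur. Compound 3 `CC1CCN(c2c(S(=O)(=O)c3cccc(C#N)c3)cnc3cc(F)ccc23)CC1` is not yet measured; it differs from compound 2 by 3-cyanophenyl in place of 3-chloro-4-fluorophenyl on a sulfonyl sulfur. That earlier step is the only one touching the same place, and it does not involve a 3-cyanophenyl, so it can only show that a change of the aryl group at this position gave a higher number in this assay. Since compound 2 sits near the top of the scale, little room for a rise remains, and compound 3 is expected to land somewhat lower, a step of a number 9 percentage points lower from compound 2 to compound 3 (within the scatter). Compound 3 is therefore estimated at 85%, between 65% and 97%.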

Compound 3, a percentage reported as inhibition, at one concentration (the size of the read-out at that concentration, not a potency): 92%
For compound 3 the middle estimate is 7 percentage points below the measured one; the range from low to high includes it.
By their numbers in this assay, from the lowest: compound 1; then compounds 3 and 2 (each within the scatter of the next).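

In this assay, the step of a number 2 percentage points lower from compound 2 to compound 3 (within the scatter) shows that 3-cyanophenyl can replace 3-chloro-4-fluorophenyl on the sulfonyl sulfur with no change beyond the scatter, so the high reading of compound 2 does not depend on chlorine or fluorine in that aryl group. The step of a number 12 percentage points higher from compound 1 to compound 3 (beyond the scatter) shows that a second aryl group, here bearing a nitrile, also stands clear of 3,5-dimethylphenyl. No measured evidence bears on why these aryl groups read as they do.

Going by these compounds, all three compounds carry a substituted phenyl ring on the sulfonyl sulfur, so it remains open how a phenyl ring bearing an amine or a carboxylic acid would read in this assay. A single concentration also leaves open whether compound 2 and compound 3 differ in potency.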